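Swapping trifluoromethyl for chloro on the hydroxy-bearing ring

The compounds below may be only part of what the source reports. "The series", "measured", "known", "first", "only" and "open" are said of these compounds alone.

Of the compounds shown here, two built on a shared core have been measured in a toxicity assay on mitochondria from liver (Rattus norvegicus) for inhibition, tested at 100 uM, in the presence of a further agent that is not named here; a higher number here means more inhibition at the concentration tested (going by the name of the read-out), a lower number less inhibition. Compound 1 `N#Cc1cc(C(=O)N2CS(=O)(=O)c3ccccc32)cc(Cl)c1O` gives 20% in this assay. Compound 2 `COc1cc(C(=O)N2CS(=O)(=O)c3ccccc32)cc(C(F)(F)F)c1O` gives 47% in this assay, the higher of the two numbers; its nearest neighbour, compound 1, lies lower by a gap that is beyond the usual scatter. Going by the values given here, no two measured compounds differ in only one place, so no single structural step has yet been followed in this assay.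

Compound 3 `COc1cc(C(=O)N2CS(=O)(=O)c3ccccc32)cc(Cl)c1O` has not been measured. It differs from compound 2 in one place: chloro in place of trifluoromethyl on an aromatic carbon. Among the compounds with values here, with no measured step to rest on, the expectation for compound 3 can draw only on the two numbers known. The gap between compound 2 and compound 1 shows that changes on this ring can shift the read-out, but compound 1 differs from compound 3 as well and gives no direct guide. For compound 3 a moderate decrease is expected, a number 12 percentage points lower from compound 2 to compound 3 (beyond the scatter). Compound 3 is estimated at 35%, within a range from 15% to 55%.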

Compound 3, a percentage reported as inhibition, at one concentration (the size of the read-out at that concentration, not a potency): 49%
The estimate for compound 3 lay 14 percentage points below the measured number; measured number inside the range.
By their numbers in this assay, from the lowest: compound 1; then compounds 2 and 3 (each within the scatter of the next).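

At the aromatic carbon ortho to a hydroxy group, chloro in place of trifluoromethyl gives a number 2 percentage points higher from compound 2 to compound 3 (within the scatter) in this assay, so with the methoxy group in place, the two groups cannot be told apart in this read-out. The other single change, methoxy in place of cyano on an aromatic carbon, gives a number 29 percentage points higher from compound 1 to compound 3 (beyond the scatter), and of the two steps only this one lies beyond the scatter; among these three compounds, then, the clear shift comes with the exchange of cyano for methoxy and not with the exchange of trifluoromethyl for chloro. No measurement at hand accounts for either step.

It remains open whether an amine, a carboxylic acid or a longer chain on the carbon ortho to the hydroxy group would leave the read-out at the same level, since the compounds shown carry only trifluoromethyl or chloro there. Also open, on these data alone, is whether trifluoromethyl and chloro would still match with cyano rather than methoxy on the ring, and how these single-concentration numbers relate to potency.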